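This account rests on a few compounds, and the source may have more. Where it says the series, first, only, none or still open, it means among the compounds named here.

Compound 1 `C[C@H](Nc1nc(O)c2cc(Cl)ccc2n1)C1CCCCC1` gives, in a functional assay on the whole organism (uterus) with Rattus norvegicus as the target, tested at 50 uM (on this read-out lower numbers stand for a stronger effect and higher numbers for a weaker effect at the one concentration tested), a value of 66.5%. Compound 2 `C[C@H](Nc1nc(O)c2cc(Cl)ccc2n1)c1ccccc1` carries phenyl in place of cyclohexyl on a saturated chain carbon bound to a nitrogen on an aromatic ring and a saturated chain carbon; in this assay compound 2 gives 44.9%, so the change made a step of a number 21.6 percentage points lower from compound 1 to compound 2 (beyond the scatter).

Compound 3 `Oc1nc(NCC2CCCCC2)nc2ccc(I)cc12` has a different core from compound 1, and the difference between the two cores is not broken down here. In this assay compound 3 gives 97.9%. Compound 4 `Oc1nc(NCc2ccccc2)nc2ccc(I)cc12` is not yet measured; it carries phenyl in place of cyclohexyl on a saturated chain carbon bound to a nitrogen on an aromatic ring. The place is described a little differently from the earlier pair, where the saturated chain carbon is also bound to another saturated chain carbon, so this is the same kind of change rather than the same change.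

Taking the earlier step as the guide, the step from compound 3 to compound 4 is expected to be about a number 20.9 percentage points lower from compound 3 to compound 4 (beyond the scatter), because compound 1 to compound 2 showed a number 21.6 percentage points lower from compound 1 to compound 2 (beyond the scatter). Compound 4 is therefore estimated at 77%, with a likely range from 60% to 93%, resting on a single earlier pair only.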

Compound 4, a percentage reported as activity, at one concentration (the size of the read-out at that concentration, not a potency): 106%
For compound 4 the middle estimate is 29 percentage points below the measured one; the measured number lies above the stated range.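

In this assay, placing phenyl where cyclohexyl stood gives a number 8.1 percentage points higher from compound 3 to compound 4 (within the scatter), so on this core the step cannot be told apart from the ordinary spread of repeated measurements. Going by these compounds alone, with only two pairs, which also differ in their cores and in the surroundings of the saturated chain carbon, the data do not show which of these differences matters, or what the swap would do on any further core. What they do show is that the step seen on one core cannot be assumed to hold on another, since the same kind of change gave clearly different steps on the two cores: the same change on two cores in this assay, a number 21.6 percentage points lower (beyond the scatter) from compound 1 to compound 2 and a number 8.1 percentage points higher (within the scatter) from compound 3 to compound 4, 29.7 percentage points apart, beyond the scatter of two such steps.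

The compounds shown leave open whether an amine or a carboxylic acid on the ring, or a longer chain in place of the single saturated chain carbon, would fit either step. They also leave open what the swap does when only the core is changed and the chain stays identical.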